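From chloro to trifluoromethyl: compound 3 to compound 4

This account rests on a few compounds, and the source may have more. Where it says the series, first, only, none or still open, it means among the compounds named here.

Compound 1 `O=C(Nc1ccccc1)c1cc2cnc(Nc3ccc(N4CCNCC4)cn3)nc2n1C1CCCC1` gives 5120 nM
Compound 2 `COc1cccc(NC(=O)c2cc3cnc(Nc4ccc(N5CCNCC5)cn4)nc3n2C2CCCC2)c1` gives 10500 nM
Compound 3 `O=C(Nc1ccccc1Cl)c1cc2cnc(Nc3ccc(N4CCNCC4)cn3)nc2n1C1CCCC1` gives 4350 nM

In a functional assay on BXPC-3 cells (Homo sapiens) for inhibition, read by MTT assay (a higher number here means a weaker inhibitor, a lower number a stronger inhibitor), compound 3 gives 4350 nM. Its nearest neighbour lies within the scatter (a 1.2-fold lower number from compound 1 to compound 3 (0.07 log units; within the scatter)), and only the gap to the methoxy-bearing compound goes beyond it (a 2.4-fold lower number from compound 2 to compound 3 (0.38 log units; beyond the scatter)).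

Compound 4 (`O=C(Nc1ccccc1C(F)(F)F)c1cc2cnc(Nc3ccc(N4CCNCC4)cn3)nc2n1C1CCCC1`) carries trifluoromethyl in place of chloro on an aromatic carbon, ortho to a large group (trifluoromethyl in place of chloro on an aromatic carbon). Within the data shown here, no measured step makes this exchange directly. The closest evidence is chloro in place of hydrogen, a step that stays within the scatter (a 1.2-fold lower number from compound 1 to compound 3 (0.07 log units; within the scatter)), while methoxy in place of hydrogen is modest (a 2.1-fold higher number from compound 1 to compound 2 (0.31 log units; beyond the scatter)). The measured steps in this series are therefore small, and none of them points to a direction for the new exchange. On this evidence, no step beyond the scatter is expected in this assay, and neither a higher nor a lower number is favoured. The estimated change is expected to stay small (a 1.1-fold higher number from compound 3 to compound 4 (0.06 log units; within the scatter)). For compound 4 the expected value is 5000 nM, with an estimated range from 2400 nM to 10500 nM.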

Compound 4, half-maximal inhibitory concentration: 8040 nM
Beside the measured number, compound 4's estimate is 1.6-fold (0.21 log units) below it; the range from low to high includes it.
By their numbers in this assay, from the lowest: compounds 3, 1, 4 and 2 (each within the scatter of the next, the first and the last beyond it).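

In this assay, trifluoromethyl, with its 4 heavy atoms, replaces the single heavy atom of chloro on the aromatic carbon ortho to a large group without a step beyond the scatter (a 1.8-fold higher number from compound 3 to compound 4 (0.27 log units; within the scatter)), and the same holds when it replaces hydrogen (a 1.6-fold higher number from compound 1 to compound 4 (0.20 log units; within the scatter)), so hydrogen, chloro and trifluoromethyl at this position cannot be told apart in this assay. Compound 4 also stays within the scatter of the compound with the 3-methoxyphenyl group (a 1.3-fold lower number from compound 2 to compound 4 (0.12 log units; within the scatter)), whereas the 2-chlorophenyl compound lies beyond it (a 2.4-fold lower number from compound 2 to compound 3 (0.38 log units; beyond the scatter)), so the 2-(trifluoromethyl)phenyl compound adds no clear separation to the series. Nothing available here accounts for these readings.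

The compounds shown leave open whether a group of another kind at this position, such as an amine, a carboxylic acid or a longer chain, would produce a step beyond the scatter. They also leave open whether methoxy would read the same at this position as it does in the 3-methoxyphenyl group, since that comparison changes both the group and its place.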